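Isopropoxy in place of the amine: compound 3

This account rests on a few compounds, and the source may have more. Where it says the series, first, only, none or still open, it means among the compounds named here.

Among the measured compounds shown here, compound 2 `CCOC(=O)C(=O)Nc1cccc(N(C)C(C)C)c1C#N` stands lowest of the two numbers so far in a functional assay on the whole organism with Rattus norvegicus as the target (on this read-out higher numbers stand for an effect only at larger amounts of compound and lower numbers for an effect already at smaller amounts), at 1.2 mg/kg; compound 1 `CCOC(=O)C(=O)Nc1cccc(N(C)C)c1C#N` gives 4.2 mg/kg, and the only measured step, a 3.5-fold lower number from compound 1 to compound 2 (0.54 log units; beyond the scatter), changes only the group on the nitrogen. Compound 3 `CCOC(=O)C(=O)Nc1cccc(OC(C)C)c1C#N` carries isopropoxy in place of isopropyl(methyl)amino on an aromatic carbon. For the measured compounds named here, no measured step exchanges the nitrogen itself for oxygen, so there is no direct guide. Since the isopropyl is kept, a step near or somewhat beyond the scatter, most likely toward a higher number, is expected in this assay, a 2.1-fold higher number from compound 2 to compound 3 (0.32 log units; beyond the scatter). Compound 3 is estimated at 2.5 mg/kg, range 0.8 mg/kg to 8 mg/kg.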

Compound 3, dose for half-maximal effect: 1 mg/kg
Compound 3: middle estimate off by 2.5-fold (0.40 log units), on the high side; measured number inside the range.
By their numbers in this assay, from the lowest: compounds 3 and 2 (each within the scatter of the next); then compound 1.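

In this assay, isopropoxy takes the place of isopropyl(methyl)amino on the aromatic carbon ortho to the cyano group with a 1.2-fold lower number from compound 2 to compound 3 (0.08 log units; within the scatter), so at this position the two groups cannot be told apart. The difference from dimethylamino remains with oxygen as the linking atom, at a 4.2-fold lower number from compound 1 to compound 3 (0.62 log units; beyond the scatter), so a nitrogen at this position is not required for a value in this range. Nothing available explains these numbers.

On these data alone, whether a shorter ether such as methoxy or a longer chain such as butoxy holds the value at this position remains open. So does the effect of a carboxylic acid in place of the ethyl ester.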